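Swapping One Halogen for Another on the Same Ring

The source may report more compounds than this note shows. Statements on the series, on what has been measured and on what is new or still open speak of the compounds shown alone.

Three measured compounds share a single core and differ only in what sits on a phenyl ring at one end. Compound 1 `COc1cc(NC(C)CCCNC(=O)Nc2ccc(Br)cc2)c2ncccc2c1` carries a bromo group; in a functional assay on NCI-H460 cells (Homo sapiens) for inhibition, read by MTT assay, with a stated time of 72 h (a lower number here means a stronger inhibitor, a higher number a weaker inhibitor), compound 1 gives 30000 nM, the highest of the three numbers and so the weakest inhibitor among them. Compound 2 `COc1cc(NC(C)CCCNC(=O)Nc2ccc(F)cc2)c2ncccc2c1` carries fluoro instead, and in this assay compound 2 gives 26000 nM; the step of a 1.2-fold lower number from compound 1 to compound 2 (0.06 log units; within the scatter) lies within the scatter, so the two read as equal. Among the compounds with values here, compound 3 `COc1cc(NC(C)CCCNC(=O)Nc2cc(C(F)(F)F)cc(C(F)(F)F)c2)c2ncccc2c1` carries two trifluoromethyl groups, and in this assay compound 3 gives 8300 nM; that number is lower than the one for compound 1 by more than the scatter, but the two structures differ in more than one place, so no single step links them.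

Compound 4 `COc1cc(NC(C)CCCNC(=O)Nc2ccc(Cl)cc2)c2ncccc2c1` is the next variation: chloro in place of bromo on an aromatic carbon. Within the data shown here, only one measured step bears on this change, the exchange of one halogen for another on the same aromatic carbon, and that step a 1.2-fold lower number from compound 1 to compound 2 (0.06 log units; within the scatter) stayed within the scatter. No direction beyond the scatter is therefore expected in this assay. For compound 4 the step of a 1.1-fold lower number from compound 1 to compound 4 (0.03 log units; within the scatter) is expected to stay within the scatter. Compound 4 is thus estimated to give about 28000 nM in this assay, with a likely range from 14000 nM to 56000 nM.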

Compound 4, half-maximal inhibitory concentration: 34000 nM
Compound 4: the middle estimate sits 1.2-fold (0.08 log units) below what was measured; the measured number falls inside the stated range.
By their numbers in this assay, from the lowest: compound 3; then compounds 2, 1 and 4 (each within the scatter of the next).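

With chloro in the series, three halogens can now be compared on the same aromatic carbon, para to a large group, instead of just two. In this assay there are two new steps, a 1.1-fold higher number from compound 1 to compound 4 (0.05 log units; within the scatter) and a 1.3-fold higher number from compound 2 to compound 4 (0.12 log units; within the scatter), and together with the earlier bromo-to-fluoro step they show that compounds 1, 2 and 4 read as equal, so exchanging any of these three halogens for another at this position produces no change that can be told from the scatter. Nothing measured here speaks to why these halogens read alike, so the result stands as an observation without an explanation.

From the compounds shown here alone, the flat result covers only fluoro, chloro and bromo, so it remains open whether a different kind of group at this position, such as an amine, a carboxylic acid or a longer carbon chain, would shift the number beyond the scatter. Compound 3 differs from these three compounds in more than one place, so it cannot show what a single change on this ring would do.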